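Compound 3 to compound 4: swapping the sulfonyl aryl group

This account rests on a few compounds, and the source may have more. Where it says the series, first, only, none or still open, it means among the compounds named here.

In a functional assay on HeLa cells (Homo sapiens) for antiproliferative activity, read by MTT assay, with a stated time of 48 h (on this read-out higher numbers stand for weaker inhibition and lower numbers for stronger inhibition), compound 1 `Cn1cc(-c2cnc3ccc(NS(=O)(=O)c4cccs4)nc3c2)cn1` gives 38400 nM and compound 2 `COc1ccc(CNc2nccc3ncc(-c4cnn(C)c4)cc23)cc1` gives 42200 nM as measured values, and these two lie within the scatter of each other. Compound 3 `Cc1ccc(S(=O)(=O)Nc2nccc3ncc(-c4cnn(C)c4)cc23)cc1` reads > 50000 nM in this assay and this is a limit of the assay, not a number. Compound 3 thus has no exact place in the series, and the record reads the limit of > 50000 nM in this assay, at which 1 of the 3 values shown sits, for now.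

Compound 4 `Cn1cc(-c2cnc3ccnc(NS(=O)(=O)c4c(Cl)cccc4Cl)c3c2)cn1` carries 2,6-dichlorophenyl in place of 4-methylphenyl on a sulfonyl sulfur and otherwise matches compound 3. Among the measured compounds shown here, no step between measured compounds gauges this change, so no step beyond the scatter is expected in this assay and no direction is favoured. For the measured compounds named here, the expectation rests on compound 1 at 38400 nM and compound 2 at 42200 nM as the only exact numbers available. The estimated step of an at least 1.1-fold lower number from compound 3 to compound 4 (0.04 log units; that floor lies within the scatter) is expected to remain within the scatter. Compound 4 is expected at 45000 nM with an estimated range from 20000 nM to 60000 nM and a real chance of a limit instead of a number.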

Compound 4, half-maximal inhibitory concentration: > 50000 nM
Compound 4: no number, only a limit; the forecaster's own chance of this, stated with the estimate: 50%; at least 1.1-fold (0.04 log units) between middle value and limit.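

Compound 4 reads > 50000 nM in this assay, and this is a limit of the assay, not a number. No step from compound 3 to compound 4 can be read, because both compounds stand only at a limit: the limit of > 50000 nM in this assay, at which 2 of the 4 values shown sit.

The compounds shown leave open whether 2,6-dichlorophenyl in place of 4-methylphenyl on a sulfonyl sulfur changes the read-out at all.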